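Cytotoxicity notes on the aryl urea semicarbazone series

The source may hold more compounds than are shown below. What is called first, only, known or untested is meant among the compounds shown, and "the series" means these compounds.

The series is followed in an ADME assay on WI-38 cells (Homo sapiens) for cytotoxicity, read by MTT assay, with a stated time of 72 h; a higher number here means a weaker inhibitor, a lower number a stronger inhibitor. For the measured compounds named here, compound 1, `CN(C)CCn1cnnc1-c1cc(Oc2ccc(NC(=O)N/N=C/c3cc(C(C)(C)C)cc(C(C)(C)C)c3O)cc2F)ccn1`, is the only member with a number so far: in this assay compound 1 gives 2350 nM. Compound 2, `CN(C)CCn1cnnc1-c1cc(Oc2ccc(NC(=O)N/N=C/c3ccc(O)c(O)c3)cc2F)ccn1`, was taken into this assay but returned no result: in this assay compound 2 stands as "not determined" (no result reported), so compound 2 has no single number to stand on; its place in the series is known only from its structure. Compound 3, `Cc1cc(/C=N/NC(=O)Nc2ccc(Oc3ccnc(-c4nncn4CCN(C)C)c3)c(F)c2)cc(C)c1O`, is not yet measured in this assay.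

Compound 3 differs from compound 2 in one place: 4-hydroxy-3,5-dimethylphenyl in place of 3,4-dihydroxyphenyl on a carbon with a double bond to nitrogen. Going by the values given here, no measured pair spans this change, so its size in this assay is unknown; the expectation is a step of no clear direction, staying within the scatter of repeat measurements. Anchored on the value of compound 1, 2350 nM, compound 3 is expected to give about 3000 nM in this assay, with the estimate ranging from 1000 nM to 10000 nM.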

Compound 3, half-maximal inhibitory concentration: 3610 nM
Compound 3: the middle estimate sits 1.2-fold (0.08 log units) below what was measured; low and high end bracket the measured number.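

No step can be read from these results: compound 2 has no number in this assay, so compound 3 has nothing to be set against. On these data alone, what the change from 3,4-dihydroxyphenyl to 4-hydroxy-3,5-dimethylphenyl does in this read-out stays open. No supporting data bear on the value of compound 3.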